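From Furan-2-yl to Furan-3-yl on the Shared Core

This account rests on a few compounds, and the source may have more. Where it says the series, first, only, none or still open, it means among the compounds named here.

Measured compounds:
- compound 1, `O=C(O)Cc1sc(C(c2ccc(F)cc2)c2ccc(F)cc2)nc1-c1cc(F)cc(F)c1`, gives 340 nM
- compound 2, `O=C(O)Cc1sc(C(c2ccc(F)cc2)c2ccc(F)cc2)nc1-c1ccco1`, gives 140 nM

Both compounds were tested in an in vitro functional assay on HEK285-7 cells for antagonist activity at prostaglandin D2 receptor 2 (Homo sapiens), read by BRET and beta-arrestin recruitment; on this read-out lower numbers stand for stronger inhibition and higher numbers for weaker inhibition. For the measured compounds named here, compound 2 stands at the lowest number of the two; the only other value belongs to compound 1, and the step of a 2.4-fold lower number from compound 1 to compound 2 (0.39 log units; beyond the scatter), which swapped a 3,5-difluorophenyl for a furan-2-yl on the shared core, is the sole measured step available.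

Compound 3, `O=C(O)Cc1sc(C(c2ccc(F)cc2)c2ccc(F)cc2)nc1-c1ccoc1`, keeps every atom of compound 2 but joins them differently: furan-3-yl in place of furan-2-yl on an aromatic carbon. Going by the values given here, no measured pair shows what moving from furan-2-yl to furan-3-yl does here. Among the compounds with values here, the one known step concerned a different exchange, so it can only say that this part of the core tolerates a small five-membered aromatic ring well. Within the data shown here, with no direct precedent, the expectation for compound 3 is a number close to that of compound 2, with the estimated step of a 1.4-fold higher number from compound 2 to compound 3 (0.15 log units; within the scatter) lying within or only just beyond the scatter. Compound 3 is therefore estimated at 200 nM, within a range from 70 nM to 600 nM.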

Compound 3, half-maximal inhibitory concentration: 130 nM
Beside the measured number, compound 3's estimate is 1.5-fold (0.19 log units) above it; the measured number falls inside the stated range.
By their numbers in this assay, from the lowest: compounds 3 and 2 (each within the scatter of the next); then compound 1.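

Moving the attachment point of the furan on the aromatic carbon next to the ring nitrogen gives a 1.1-fold lower number from compound 2 to compound 3 (0.03 log units; within the scatter) in this assay, so this read-out does not separate furan-2-yl from furan-3-yl, although the oxygen lies in a different place relative to the shared core. The lower number seen with a furan in place of 3,5-difluorophenyl therefore holds for both ways of joining the ring: alongside the earlier 2.4-fold lower number from compound 1 to compound 2 (0.39 log units; beyond the scatter), the new comparison gives a 2.6-fold lower number from compound 1 to compound 3 (0.42 log units; beyond the scatter), and both steps lie beyond the scatter. Nothing available here explains why the point of attachment makes so little difference at this position. 

The compounds shown leave open whether the ring oxygen itself matters, which a five-membered aromatic ring with sulfur in its place could test. They also leave open how much room remains on the furan-3-yl, for example for an added methyl group or an amine, and whether its behaviour would match that of furan-2-yl carrying the same group.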